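Iodo in place of nitro: working notes

A few compounds are considered here, and "the series" means these few. Any claim that something is new, unique, unknown or untested is made for them only; others in the source may bear on it.

Values in a functional assay on T98G cells (Homo sapiens) for cytotoxicity, read by MTT assay, with a stated time of 48 h; on this read-out higher numbers stand for weaker inhibition and lower numbers for stronger inhibition:
- compound 1 `C/C(=N\NC(=S)Nc1ccc(I)cc1)c1ccccn1` gives 64 nM
- compound 2 `C/C(=N/NC(=S)Nc1ccc([N+](=O)[O-])cc1)c1ccccn1` gives 140 nM
- compound 3 `CC(=NNC(=S)Nc1ccc([N+](=O)[O-])cc1)c1ccccn1` gives 140 nM

Compound 3 and compound 2 share the highest number of the three, while compound 1, which carries iodo, lies lower, beyond the scatter. Compound 4 `C/C(=N/NC(=S)Nc1ccc(I)cc1)c1ccccn1` differs from compound 2 by iodo in place of nitro on an aromatic carbon with iodo in place of nitro on an aromatic carbon. Going by the values given here, the one measured step is no change at the digits printed from compound 2 to compound 3 (within the scatter) and concerns only the fact that one of compounds 2 and 3 is drawn with a defined configuration and the other without, at the place where they differ without touching the nitro group. Among the compounds with values here, the sole guide to iodo is compound 1 at 64 nM in this assay and that number points downward. The expected step is a 2.0-fold lower number from compound 2 to compound 4 (0.30 log units; within the scatter) toward stronger inhibition. For compound 4 the estimated value is 70 nM (expected range 30 nM to 150 nM).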

Compound 4, half-maximal inhibitory concentration: 64 nM
Compound 4: middle estimate off by 1.1-fold (0.04 log units), on the high side; the measured number falls inside the stated range.
By their numbers in this assay, from the lowest: compounds 1 and 4 (each within the scatter of the next); then compounds 2 and 3 (each within the scatter of the next).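

In this assay iodo in place of nitro on an aromatic carbon now has a direct reading, with the double bond drawn the same way in both compounds (a 2.2-fold lower number from compound 2 to compound 4 (0.34 log units; beyond the scatter)). The two iodo compounds read alike (no change at the digits printed from compound 1 to compound 4 (within the scatter)), so drawn configuration shows no visible effect with iodo, as already seen with nitro. The iodo pair therefore rests on a single difference: (the fact that compounds 1 and 4 differ only in the configuration as drawn).

Only iodo and nitro are shown at this place on the aromatic ring. As far as these compounds go, whether an amine, a carboxylic acid or a methoxy group would read with iodo, with nitro or elsewhere stays open.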